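Bromo to ethynyl on the anilino arm of compound 1

The compounds below may be only part of what the source reports. "The series", "measured", "known", "first", "only" and "open" are said of these compounds alone.

Among the compounds with values here, compound 1 `Nc1ccccc1NC(=O)c1ccc(COc2ccc3ncnc(Nc4cccc(Br)c4)c3c2)cc1` gives the lowest number of the two so far in a functional assay on SK-OV-3 cells (Homo sapiens) for cytotoxicity, read by resazurin assay (on this read-out lower numbers stand for stronger inhibition and higher numbers for weaker inhibition), at 6300 nM. Compound 2 `C#Cc1cccc(Nc2ncnc3cc(NC(=O)c4ccc(C(=O)Nc5ccccc5N)s4)ccc23)c1`, built on a different linkage, gives 30000 nM in this assay, a gap that lies beyond the usual scatter. The step from compound 1 to compound 3 `C#Cc1cccc(Nc2ncnc3ccc(OCc4ccc(C(=O)Nc5ccccc5N)cc4)cc23)c1` is a single change: ethynyl in place of bromo on an aromatic carbon. Within the data shown here, no measured pair shows this change, so the account rests on compound 1 alone; the step from compound 1 to compound 3 is expected to be small, within the scatter, as a 1.3-fold lower number from compound 1 to compound 3 (0.10 log units; within the scatter). Compound 3 is therefore estimated at 5000 nM, in a range from 1500 nM to 15000 nM.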

Compound 3, half-maximal inhibitory concentration: 5100 nM
Compound 3: middle estimate off by 1.0-fold (0.01 log units), on the low side, within the range that was stated.
By their numbers in this assay, from the lowest: compounds 3 and 1 (each within the scatter of the next); then compound 2.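

Going from 3-bromophenyl to 3-ethynylphenyl gives a 1.2-fold lower number from compound 1 to compound 3 (0.09 log units; within the scatter), the only measured pair that changes this position. On this core, then, the aromatic carbon carries ethynyl in place of bromo, with one more heavy atom, and the number stays within the scatter. No measurement shown here accounts for why the two groups read alike. The compounds leave open whether an amine or a carboxylic acid on this carbon would move the number beyond the scatter. On these data alone, a longer chain ending in a triple bond also remains open.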